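Swapping a Furan for a Hydroxyphenyl Sulfide

The source may report more compounds than this note shows. Statements on the series, on what has been measured and on what is new or still open speak of the compounds shown alone.

Compound 2 `Cc1cc(-c2ccco2)c2ncc(CSCCc3ccccc3)n2c1` gives 41 ug/mL in an ADME assay on HEL cells (Homo sapiens) for cytotoxicity, with a stated time of 3 days (a higher number here means that more compound is tolerated, a lower number that less compound is tolerated), and compound 1 `Cc1cc(N2CCN(C)CC2)cn2c(CSCCc3ccccc3)cnc12` gives 32 ug/mL; the two values lie within the usual scatter of each other, so neither compound stands apart. Compound 3 `Cc1cc(Sc2ccc(O)cc2)c2ncc(CSCCc3ccccc3)n2c1` differs from compound 2 by (4-hydroxyphenyl)sulfanyl in place of furan-2-yl on an aromatic carbon. Among the measured compounds shown here, no measured pair shows what this change does to tolerated concentration, so the step of a 1.0-fold lower number from compound 2 to compound 3 (0.01 log units; within the scatter) is expected to be small, with no clear direction beyond the scatter. Compound 3 is therefore estimated at 40 ug/mL, with a likely range from 20 ug/mL to 80 ug/mL.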

Compound 3, half-maximal cytotoxic concentration: 79 ug/mL
Beside the measured number, compound 3's estimate is 2.0-fold (0.30 log units) below it; measured number inside the range.
By their numbers in this assay, from the lowest: compounds 1, 2 and 3 (each within the scatter of the next, the first and the last beyond it).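

Among the compounds shown here, this is the first step measured at this aromatic carbon, and the change gives a 1.9-fold higher number from compound 2 to compound 3 (0.28 log units; within the scatter) in this assay. So (4-hydroxyphenyl)sulfanyl, with more heavy atoms than furan-2-yl and a hydrogen-bond donor, does not move the tolerated concentration beyond the scatter. Nothing measured here offers an explanation for the step.

Which part of the entering group counts, the sulfur or the hydroxyl, remains open. So does whether an amine or a carboxylic acid on this carbon would give a step beyond the scatter.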